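Series notes: compound 2 to compound 4 in permeability

The compounds below may be only part of what the source reports. "The series", "measured", "known", "first", "only" and "open" are said of these compounds alone.

Compound 2 `CCC(CC)c1ccc2c(NCCCNCc3cccc(OC)c3O)ccnc2c1` gives 23 10^-6 cm/s in an ADME assay for permeability, using PAMPA, with a stated time of 30 min, at pH 7.4; on this read-out higher numbers stand for higher permeability and lower numbers for lower permeability. Compound 1 `COc1cccc(CNCCCNc2ccnc3cc(Cc4ccccc4)ccc23)c1O` gives 23 10^-6 cm/s, level with compound 2 within the scatter; together they hold the lowest numbers of the three. Compound 3 `COc1ccc(F)cc1CNCCCNc1ccnc2cc(Oc3ccc(C(C)(C)C)cc3)ccc12` gives 317 10^-6 cm/s, a higher number beyond the scatter. The change to compound 4 `COc1cccc(CNCCCNc2ccnc3cc(Cc4ccc(C#N)cc4)ccc23)c1O` is 4-cyanobenzyl in place of pentan-3-yl on an aromatic carbon. Within the data shown here, one measured step bears on it: no change at the digits printed from compound 1 to compound 2 (within the scatter), the same aromatic carbon carrying either benzyl or pentan-3-yl with no shift in the read-out. Compound 4 carries a benzyl again, now bearing a nitrile. Among the measured compounds shown here, with the only related step flat, the move is expected to stay within the scatter, a 1.2-fold lower number from compound 2 to compound 4 (0.06 log units; within the scatter). Compound 4 is estimated at 20 10^-6 cm/s, ranging from 9 10^-6 cm/s to 45 10^-6 cm/s.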

Compound 4, apparent permeability: 23 10^-6 cm/s
Compound 4: the middle estimate sits 1.2-fold (0.06 log units) below what was measured; measured number inside the range.
By their numbers in this assay, from the lowest: compounds 1, 2 and 4 (each within the scatter of the next); then compound 3.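

With a third group on this aromatic carbon, this assay shows no change at the digits printed from compound 2 to compound 4 (within the scatter), so 4-cyanobenzyl joins benzyl and pentan-3-yl on the same flat level. The nitrile itself also leaves the read-out unmoved, with no change at the digits printed from compound 1 to compound 4 (within the scatter) on the benzyl group. Nothing available accounts for this flatness.

From the compounds shown here alone, whether an amine or a carboxylic acid on this aromatic carbon would keep the read-out level stays open. Also open, going by these compounds, is whether a substituent other than the nitrile on the benzyl ring would do the same.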